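This account rests on a few compounds, and the source may have more. Where it says the series, first, only, none or still open, it means among the compounds named here.

Compound 1 `CC#C[C@@H](CC(=O)O)c1ccc(OC[C@H]2COc3ccc(OC(C)C)cc3O2)cc1`: 280 nM in a functional assay on HEK293 cells for agonist activity at Free fatty acid receptor 1 (Homo sapiens), read by fluorescence and calcium flux, with a stated time of 10 min; a lower number here means that less compound is needed, a higher number that more compound is needed for the effect.
Compound 2 `CC#C[C@@H](CC(=O)O)c1ccc(OC[C@H]2COc3ccc(C(C)=O)cc3O2)cc1`: compound 2 reaches only the limit of this assay, > 30000 nM.

Compound 2 thus stands at the limit (the limit of > 30000 nM in this assay, at which 1 of the 2 values shown sits), the weaker of the two measured values, reached through an at least 100-fold higher number from compound 1 to compound 2 (2.02 log units; beyond the scatter). Compound 3 `CC#C[C@@H](CC(=O)O)c1ccc(OC[C@H]2COc3ccc(C(=O)N(C)C)cc3O2)cc1` differs from compound 2 by dimethylamino in place of methyl on a carbonyl carbon. Going by the values given here, no measured step alters the substituent on the carbonyl carbon itself; the only measured step, an at least 100-fold higher number from compound 1 to compound 2 (2.02 log units; beyond the scatter), exchanges the whole group for acetyl. Since compound 2 sits at the limit, nothing shown points to a recovery, and the expected step is a number no higher from compound 2 to compound 3 (the limit leaves the size open), with a fair chance that compound 3 again returns only a limit. The estimate for compound 3 is 30000 nM, range 5000 nM to 100000 nM.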

Compound 3, half-maximal effective concentration: > 30000 nM
Compound 3: a limit, no number; the forecaster's own chance of this, stated with the estimate: 60%; the middle value sits exactly at the limit.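

In this assay, swapping the isopropoxy group for dimethylcarbamoyl gives an at least 100-fold higher number from compound 1 to compound 3 (2.02 log units; beyond the scatter), so acetyl is no longer the only replacement with this outcome. Both compounds with a carbonyl carbon on that aromatic carbon now stand at a limit, not a number: the limit of > 30000 nM in this assay, at which 2 of the 3 values shown sit. The step between compound 2 and compound 3 cannot be read, so the two groups cannot be ranked.

Whether the carbonyl link or the loss of the isopropoxy group accounts for these results stays open. Methoxy or ethoxy on the same aromatic carbon would bear on this.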